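The compounds below may be only part of what the source reports. "The series", "measured", "known", "first", "only" and "open" are said of these compounds alone.

Measured in a physicochemical assay for solubility, read by HPLC, with a stated time of 24 h; a higher number here means a more soluble compound, a lower number a less soluble compound:
- Compound 1 `O=C(c1ccccc1)c1cccc(/C=c2\[nH]c(=O)/c(=C/c3ccccn3)[nH]c2=O)c1`: < 0.1 ug/mL, a limit
- Compound 2 `CC(C)(C)c1[nH]cnc1/C=c1\[nH]c(=O)/c(=C/c2cccc(C(=O)N3CCCC3)c2)[nH]c1=O`: 0.454 ug/mL
- Compound 3 `O=C(c1cccc(/C=c2\[nH]c(=O)/c(=C/c3ccccn3)[nH]c2=O)c1)N1CCCCC1`: < 0.1 ug/mL, a limit

Among the measured compounds shown here, compound 2 holds the only true number here, and the other two results are limits. Compound 4 `CC(C)(C)c1[nH]cnc1/C=c1\[nH]c(=O)/c(=C/c2cccc(C(=O)c3cccs3)c2)[nH]c1=O` changes one group of compound 2: thiophen-2-yl in place of pyrrolidin-1-yl on a carbonyl carbon. The nearest measured step is a step that the two limits leave unreadable from compound 1 to compound 3, with piperidin-1-yl in place of phenyl on a carbonyl carbon. It rests on (the limit of < 0.1 ug/mL in this assay, at which 2 of the 3 values shown sit), so it offers no size. Compound 1, with phenyl on that carbonyl carbon, shows < 0.1 ug/mL, which is a limit. Compound 3 sits at the same limit with piperidin-1-yl, so this is only a weak pointer. The expected change is a modest fall, a 2.3-fold lower number from compound 2 to compound 4 (0.36 log units; beyond the scatter). For compound 4 the estimated value is 0.2 ug/mL, with an expected range of 0.07 ug/mL to 0.55 ug/mL.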

Compound 4, solubility: < 0.1 ug/mL
Compound 4: no number, only a limit; the forecaster's own chance of this, stated with the estimate: 35%; at least 2.0-fold (0.30 log units) between middle value and limit.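

In this assay, among the compounds shown here, putting thiophen-2-yl in place of pyrrolidin-1-yl on the carbonyl carbon gives an at least 4.5-fold lower number from compound 2 to compound 4 (0.65 log units; beyond the scatter) and this is the first change at this place with any readable size. Compound 4 gives only a limit, so that size is a minimum and not a measured gap: the limit of < 0.1 ug/mL in this assay, at which 3 of the 4 values shown sit.

The step from compound 1 to compound 3 still cannot be read. From the compounds shown here alone, whether a carbonyl carbon bearing an open-chain amine such as dimethylamino, or a carboxylic acid in place of the whole carbonyl group, would read higher than compound 2 remains open.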